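Compound 2 to compound 3: trifluoromethyl replaced by hydrogen

A few compounds are considered here, and "the series" means these few. Any claim that something is new, unique, unknown or untested is made for them only; others in the source may bear on it.

Measured so far in a functional assay on SK-BR-3 cells (Homo sapiens) for cytotoxicity, read by MTT assay, with a stated time of 72 h (on this read-out lower numbers stand for stronger inhibition and higher numbers for weaker inhibition), for this series
- compound 1 `C[C@H](NC(=O)c1nc(Br)c2cccnc2c1N[C@H]1CC[C@H](N)CC1)c1ccc(F)cc1` gives 9000 nM
- compound 2 `N[C@H]1CC[C@H](Nc2c(C(=O)NCc3cccc(C(F)(F)F)c3)nc(Br)c3cccnc23)CC1` gives "not determined" (no result reported)

Compound 2 has no single number to stand on. Next in line is compound 3 `N[C@H]1CC[C@H](Nc2c(C(=O)NCc3ccccc3)nc(Br)c3cccnc23)CC1`, still unmeasured. The change hydrogen in place of trifluoromethyl on an aromatic carbon puts hydrogen in place of trifluoromethyl on an aromatic carbon, taking 3-(trifluoromethyl)benzyl to benzyl. Going by the values given here, without a number for compound 2, no step in this assay can be sized, and none beyond the scatter is expected. Among the compounds with values here, the only measured reference is compound 1 (9000 nM). For compound 3 the estimated value is 7000 nM, with an expected range from 2000 nM to 25000 nM in this read-out.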

Compound 3, half-maximal inhibitory concentration: 8000 nM
For compound 3 the middle estimate is 1.1-fold (0.06 log units) below the measured one, and the stated range covers the measured number.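

In this assay, benzyl in place of 1-(4-fluorophenyl)ethyl on the amide-type nitrogen gives a 1.1-fold lower number from compound 1 to compound 3 (0.05 log units; within the scatter), so this position now has two substituents that the read-out does not separate. As far as these compounds go, the step that removes trifluoromethyl cannot be read: compound 2 has no number, and the size of this change remains unknown. No measurement at hand offers a cause for these results.

Open, from the compounds shown here alone, is whether an amine or a carboxylic acid on the benzyl ring, or a longer chain in place of benzyl, would shift the number in this assay beyond the scatter.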